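From a Hexyl Ester to an Ether-Chain Ester

The source may hold more compounds than are shown below. What is called first, only, known or untested is meant among the compounds shown, and "the series" means these compounds.

Compound 1 `CCOC(=O)c1cccc(-c2ccc3c(ccn3C)c2)c1` gives 84% in an assay on COS-7 cells for inhibition of patatin-like phospholipase domain-containing protein 2 (Mus musculus), tested at 200 uM; a higher number here means more inhibition at the concentration tested (going by the name of the read-out), a lower number less inhibition.
Compound 2 `CCOc1ccc(-c2cccc(C(=O)O)c2)cc1` gives 23% in this assay.
Compound 3 `CCCCCCOC(=O)c1cccc(-c2ccc(OCC)cc2)c1` gives 48% in this assay.

Compound 3 stands second highest of the three numbers. Its nearest neighbour is compound 2, which sits lower by a gap beyond the scatter, and compound 1, the furthest, sits higher, also beyond the scatter. Within the data shown here, the only step between compounds that differ in one place is a number 25 percentage points higher from compound 2 to compound 3 (beyond the scatter), hexyl in place of hydrogen on an oxygen next to a carbonyl group, a modest rise.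

Compound 4 `CCOc1ccc(-c2cccc(C(=O)OCCOCCOC)c2)cc1` differs from compound 3 by 2-methoxyethoxy in place of butyl on a saturated chain carbon, two bonds along the chain from an oxygen next to a carbonyl group. Among the measured compounds shown here, no measured step touches this part of the chain. For the measured compounds named here, the one step on record shows only that the hexyl ester inhibits more than the free acid, and compound 4 remains an ester. Compound 1 differs from compound 3 in more than one place, so its value says nothing direct about this change. Compound 4 is therefore expected to stay near compound 3, and the step of a number 6 percentage points lower from compound 3 to compound 4 (within the scatter) is expected to lie within the scatter. The estimate for compound 4 in this assay is 42%, with a range from 20% to 65%.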

Compound 4, a percentage reported as inhibition, at one concentration (the size of the read-out at that concentration, not a potency): 43%
Estimate against measurement, compound 4: 1 percentage points below; low and high end bracket the measured number.
By their numbers in this assay, from the lowest: compound 2; then compounds 4 and 3 (each within the scatter of the next); then compound 1.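

In this assay, 2-methoxyethoxy in place of butyl on a saturated chain carbon, two bonds along the chain from an oxygen next to a carbonyl group, gives a number 5 percentage points lower from compound 3 to compound 4 (within the scatter) and so shows that, at this position, the ether chain and the all-carbon chain cannot be told apart in this read-out. Among these compounds, the free acid had so far been compared only with the hexyl ester, which gave a number 25 percentage points higher from compound 2 to compound 3 (beyond the scatter) as its step, and the 2-(2-methoxyethoxy)ethyl ester now gives a number 20 percentage points higher from compound 2 to compound 4 (beyond the scatter) as well, so the gain over the acid is not tied to an all-carbon ester chain. No measurement at hand explains this, and the result stands as a description of the numbers.

Still open, as far as these compounds go, is whether a longer chain, or a chain ending in an amine, would keep the number at this level. Compound 1 at 84% remains apart, since no compound shown separates the contribution of its core from that of its ethyl ester.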